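Chain-end change from compound 2 to compound 3

The compounds below may be only part of what the source reports. "The series", "measured", "known", "first", "only" and "open" are said of these compounds alone.

Measured so far in a functional assay (aorta) with Oryctolagus cuniculus as the target; a lower number here means tighter binding, a higher number weaker binding:
- compound 1 `COc1cc(C(=O)O)ccc1OCCCN1CCC(C(c2ccc(F)cc2)c2ccc(F)cc2)CC1` at 79.4 nM
- compound 2 `Fc1ccc(C(c2ccc(F)cc2)C2CCN(CCCOc3cccc4ccccc34)CC2)cc1` at 5.01 nM

Compound 2 holds the lower of the two numbers. Compound 3 `Fc1ccc(C(c2ccc(F)cc2)C2CCN(CCCCc3ccccc3)CC2)cc1` differs from it by benzyl in place of (naphthalen-1-yl)oxy on a saturated chain carbon, three bonds along the chain from an amine nitrogen in a ring and carries benzyl in place of (naphthalen-1-yl)oxy on a saturated chain carbon, three bonds along the chain from an amine nitrogen in a ring. For the measured compounds named here, only one measured step bears on this, the large 16-fold lower number from compound 1 to compound 2 (1.20 log units; beyond the scatter) for naphthalen-1-yl in place of 4-carboxy-2-methoxyphenyl on an oxygen on a saturated carbon. That step is a different change, so only a modest rise in this assay is expected, and its size is poorly fixed. The expected change is a 2.4-fold higher number from compound 2 to compound 3 (0.38 log units; beyond the scatter) as an estimate. Compound 3 is estimated at 12 nM within an expected range of 3 nM to 50 nM.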

Compound 3, dissociation constant: 2.51 nM
For compound 3 the middle estimate is 4.8-fold (0.68 log units) above the measured one, outside the stated range (below it).
By their numbers in this assay, from the lowest: compounds 3 and 2 (each within the scatter of the next); then compound 1.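

In this assay, the chain end tolerates loss of the oxygen and one of the two aromatic rings: benzyl in place of (naphthalen-1-yl)oxy gives a 2.0-fold lower number from compound 2 to compound 3 (0.30 log units; within the scatter) and thus no separation between these two compounds. Benzyl in place of 4-carboxy-2-methoxyphenoxy gives a 32-fold lower number from compound 1 to compound 3 (1.50 log units; beyond the scatter) and shows that a plain carbon chain end also suffices for a large step away from compound 1. No supporting data bear on either step.

Still open, as far as these compounds go, is how a longer chain between the ring nitrogen and the phenyl ring would read. Also open, from the compounds shown here alone, is whether an amine or a carboxylic acid on that phenyl ring would alone move the number as far as the compound 1 chain end does.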